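The source may hold more compounds than are shown below. What is called first, only, known or untested is meant among the compounds shown, and "the series" means these compounds.

The series rests on a shared core carrying two furan-derived amide groups, shown in compound 1 `C[Se]/C(=N\C(=O)c1ccco1)NC(=O)c1ccco1` with a methylselanyl group and in compound 2 `CS/C(=N\C(=O)c1ccco1)NC(=O)c1ccco1` with a methylsulfanyl group. In a functional assay on HepG2 cells (Homo sapiens) for cytotoxicity, read by MTT assay, with a stated time of 72 h (a lower number here means a stronger inhibitor of growth, a higher number a weaker inhibitor of growth), compound 1 gives 760 nM. In this assay compound 2 reaches only a limit, > 100000 nM. The change from compound 1 to compound 2 is thus an at least 130-fold higher number from compound 1 to compound 2 (2.11 log units; beyond the scatter), and its true size is open because compound 2 sits at the limit of > 100000 nM in this assay, at which 1 of the 3 values shown sits. Compound 3 `O=C(/N=C(/NC(=O)c1cccs1)[Se]Cc1ccccc1)c1cccs1`, a thiophene analogue bearing a benzylselanyl group, gives 34700 nM in this assay. Compound 4 `O=C(/N=C(/NC(=O)c1ccco1)[Se]Cc1ccccc1)c1ccco1` has not yet been measured in this assay. Its difference from compound 2 is a group of 8 heavy atoms (7 carbon, 1 selenium; one six-membered aromatic ring of carbon only) in place of a group of 2 heavy atoms (1 carbon, 1 sulfur; no ring), on a carbon with a double bond to nitrogen. The return of selenium reverses the direction of the step from compound 1 to compound 2, and compound 3 shows what a benzylselanyl group yields on a related core, so a large step toward stronger growth inhibition is expected: an at least 5.0-fold lower number from compound 2 to compound 4 (0.69 log units; beyond the scatter). Compound 4 is therefore estimated at 20000 nM, within 3000 nM to 100000 nM.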

Compound 4, concentration for 50% growth inhibition: 7650 nM
The estimate for compound 4 lay 2.6-fold (0.42 log units) above the measured number; the measured number falls inside the stated range.
By their numbers in this assay, from the lowest: compound 1; then compound 4; then compound 3. At a limit, above all of these: compound 2.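

On the carbon with a double bond to nitrogen, enlarging the selenium-bearing group has a cost: in this assay, phenyl in place of hydrogen on the saturated chain carbon bound to selenium gives a 10-fold higher number from compound 1 to compound 4 (1.00 log units; beyond the scatter). Even with that cost, the benzylselanyl group keeps a clear margin over methylsulfanyl on the furan-bearing core, with an at least 13-fold lower number from compound 2 to compound 4 (1.11 log units; beyond the scatter). The true size of this second step stays open, since compound 2 stands at a limit: the limit of > 100000 nM in this assay, at which 1 of the 4 values shown sits.

The step from compound 2 to compound 4 changes the chain and the selenium together, so the compounds shown do not separate the two, and a benzylsulfanyl group at this carbon would be needed to do so. On these data alone, how a longer chain, such as ethylselanyl, would fall relative to methylselanyl and benzylselanyl also remains open.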